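Methyl in Place of Chloro in Two Substance-P Receptor Series

The source may hold more compounds than are shown below. What is called first, only, known or untested is meant among the compounds shown, and "the series" means these compounds.

Three compounds have been measured in an assay on CHO cells for displacement of a labelled ligand from Substance-P receptor (Homo sapiens); on this read-out lower numbers stand for stronger inhibition and higher numbers for weaker inhibition:

Compound 1, `Clc1ccccc1-c1ccccc1/C=N/Nc1c(Cl)cncc1Cl`: 174 nM
Compound 2, `Cc1ccccc1-c1ccccc1/C=N/Nc1c(Cl)cncc1Cl`: 316 nM
Compound 3, `CN(Cc1cc(C(F)(F)F)cc(C(F)(F)F)c1)C(=O)c1ccccc1-c1ccccc1Cl`: 22 nM

Compound 1 and compound 2 share one core and differ only in one place: methyl in place of chloro on an aromatic carbon. In this assay this change gives a 1.8-fold higher number from compound 1 to compound 2 (0.26 log units; within the scatter), so the two values cannot be told apart with confidence.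

Compound 3 rests on a different core; the difference between the two cores is not broken down here. Compound 3 shows the lowest number of the three, and its gap to compound 1 and to compound 2 is beyond the scatter in each case.

Compound 4, `Cc1ccccc1-c1ccccc1C(=O)N(C)Cc1cc(C(F)(F)F)cc(C(F)(F)F)c1`, has not yet been measured. It differs from compound 3 by methyl in place of chloro on an aromatic carbon, the same change that turns compound 1 into compound 2, at a place described in the same words. The step from compound 3 to compound 4 in this assay is therefore expected to be of similar size, a 1.8-fold higher number from compound 3 to compound 4 (0.26 log units; within the scatter), because the earlier pair gave a 1.8-fold higher number from compound 1 to compound 2 (0.26 log units; within the scatter). On that basis compound 4 is estimated at 40 nM, most likely between 15 nM and 110 nM.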

Compound 4, inhibition constant: 17 nM
Compound 4: the middle estimate sits 2.4-fold (0.37 log units) above what was measured; the range from low to high includes it.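

In this assay, methyl in place of chloro gives a 1.3-fold lower number from compound 3 to compound 4 (0.11 log units; within the scatter), so the two values cannot be told apart with confidence. Set beside the earlier step, the change behaves alike on both cores, and the opposite directions of the two steps carry no weight: the same change on two cores in this assay, a 1.8-fold higher number (0.26 log units; within the scatter) from compound 1 to compound 2 and a 1.3-fold lower number (0.11 log units; within the scatter) from compound 3 to compound 4, 2.4-fold (0.37 log units) apart, within the scatter of two such steps This shows that, on these two cores, the swap leaves the number within the scatter, but it rests on only two pairs and does not show that the same would hold on a third core or that the two groups are interchangeable in general.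

The compounds shown hold only chloro and methyl at this place, so it remains open whether a fluoro group, a methoxy group or a nitrile there would also leave the number within the scatter on both cores. On these data alone, it also remains open whether the swap would behave the same way in any read-out other than this assay.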